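A few compounds are considered here, and "the series" means these few. Any claim that something is new, unique, unknown or untested is made for them only; others in the source may bear on it.

Measured in an ADME assay on MRC5 cells (Homo sapiens) for cytotoxicity, read by MTT assay, with a stated time of 72 h; a lower number here means a stronger inhibitor of growth, a higher number a weaker inhibitor of growth:
- Compound 1 `COc1ccc(CS(=O)(=O)/C=C/c2c(OC)cccc2OC)cc1[N+](=O)[O-]`: > 30000 nM (a limit)
- Compound 2 `COc1ccc(CS(=O)(=O)/C=C/c2c(OC)cccc2OC)cc1N`: 17100 nM

Compound 1 has no number in this assay, only a limit: the limit of > 30000 nM in this assay, at which 1 of the 2 values shown sits. Compound 3 `COc1cc(OC)c(/C=C/S(=O)(=O)Cc2ccc(OC)c([N+](=O)[O-])c2)c(OC)c1` keeps the core of compound 1 and carries methoxy in place of hydrogen on an aromatic carbon, methoxy in place of hydrogen on an aromatic carbon. Within the data shown here, the one measured step, an at least 1.7-fold lower number from compound 1 to compound 2 (0.24 log units; that floor lies within the scatter), changes a different place, so it bears only indirectly. It gives a rough size for a single change in this series. A modest move toward a lower number is therefore expected, though compound 3 may also stay at the limit. The expected change is an at least 2.0-fold lower number from compound 1 to compound 3 (0.30 log units; that floor lies within the scatter). For compound 3 the estimated value is 15000 nM, with an expected range of 2000 nM to 40000 nM.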

Compound 3, concentration for 50% growth inhibition: 2910 nM
Beside the measured number, compound 3's estimate is 5.2-fold (0.71 log units) above it; low and high end bracket the measured number.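

In this assay, methoxy in place of hydrogen on an aromatic carbon, para to a large group and meta to two methoxy groups, gives an at least 10-fold lower number from compound 1 to compound 3 (1.01 log units; beyond the scatter). This place on the ring, not the one changed in the earlier step, is thus the first where a single change clearly moves the number. The step remains only a floor because compound 1 has a limit rather than a number: the limit of > 30000 nM in this assay, at which 1 of the 3 values shown sits.

On these data alone, what a hydroxyl, an ethoxy or an amine would do at this place stays open. So does whether amino in place of nitro would add to the methoxy change.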